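The source may hold more compounds than are shown below. What is called first, only, known or untested is meant among the compounds shown, and "the series" means these compounds.

Measured so far in a functional assay on M21 cells (Homo sapiens) for antiproliferative activity, read by sulforhodamine B assay, with a stated time of 48 h; a lower number here means a stronger inhibitor, a higher number a weaker inhibitor:
- compound 1 `CN1CCN(c2ccc(S(=O)(=O)Oc3cccc(F)c3)cc2)C1=O`: 5800 nM
- compound 2 `CN1CCN(c2ccc(S(=O)(=O)Oc3cccc(Cl)c3)cc2)C1=O`: 1600 nM
- compound 3 `CN1CCN(c2ccc(S(=O)(=O)Oc3cccc(Br)c3)cc2)C1=O`: 1300 nM

Compound 3 sits at 1300 nM and shares the low end of the set with compound 2. The gap within that pair lies inside the scatter: a 1.2-fold lower number from compound 2 to compound 3 (0.09 log units; within the scatter). The fluoro analogue stands apart: a 4.5-fold lower number from compound 1 to compound 3 (0.65 log units; beyond the scatter).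

Next is compound 4 `CN1CCN(c2ccc(S(=O)(=O)Oc3ccc(F)cc3)cc2)C1=O`: 4-fluorophenyl in place of 3-bromophenyl on an oxygen. The nearest guide is that bromo-to-fluoro contrast, read in reverse, with a 3.6-fold lower number from compound 1 to compound 2 (0.56 log units; beyond the scatter) in support. Going by the values given here, no measured compound carries 4-fluorophenyl, so this guide is only partial. In this assay, a modest rise beyond the scatter is expected. For compound 4, the expected step is a 4.6-fold higher number from compound 3 to compound 4 (0.66 log units; beyond the scatter). Compound 4 is estimated at 6000 nM, within 2500 nM to 15000 nM.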

Compound 4, half-maximal inhibitory concentration: > 100000 nM
Compound 4 gave a limit, no number (the forecaster's own chance of this, stated with the estimate: 5%); at least 16-fold (1.22 log units) between middle value and limit.
By their numbers in this assay, from the lowest: compounds 3 and 2 (each within the scatter of the next); then compound 1. At a limit, above all of these: compound 4.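

In this assay compound 4 gives a limit of the assay, not a number: the limit of > 100000 nM in this assay, at which 1 of the 4 values shown sits. Keeping the halogen and going from 3-fluorophenyl to 4-fluorophenyl still brings an at least 17-fold higher number from compound 1 to compound 4 (1.23 log units; beyond the scatter), so on this oxygen-bound phenyl, where the fluoro sits counts for more than the halogen swaps among compounds 1, 2 and 3 showed. The two steps that also change the halogen are large too: an at least 62-fold higher number from compound 2 to compound 4 (1.79 log units; beyond the scatter), and an at least 76-fold higher number from compound 3 to compound 4 (1.88 log units; beyond the scatter).

Open, on these data alone, is whether 4-chlorophenyl or 4-bromophenyl would also lose activity this far. As far as these compounds go, what an amine or a methoxy group on this phenyl would do also stays open.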